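Replacing the phenyl of compound 1

The compounds below may be only part of what the source reports. "The series", "measured", "known", "first", "only" and "open" are said of these compounds alone.

Values so far in a physicochemical assay for lipophilicity, at pH 7.4; on this read-out higher numbers stand for higher lipophilicity and lower numbers for lower lipophilicity
Compound 1 `CN(Cc1ccc2nccn2c1)c1nnc(-c2ccc(-c3ccccc3)cc2)o1` gives 3.9
Compound 2 `CN(Cc1ccc2nccn2c1)c1nnc(-c2ccc(-c3ccccc3F)cc2)o1` gives 4.4
Compound 3 `CN(Cc1ccc2nccn2c1)c1nnc(-c2ccc(-c3ccccc3C#N)cc2)o1` gives 3.6

Compound 1 lies within the scatter of compound 3 and under compound 2. In compound 4 `Cc1ncccc1-c1ccc(-c2nnc(N(C)Cc3ccc4nccn4c3)o2)cc1` 2-methylpyridin-3-yl stands in place of phenyl on an aromatic carbon (2-methylpyridin-3-yl in place of phenyl on an aromatic carbon). Two measured steps alter that same phenyl: fluoro in place of hydrogen gave a number 0.50 log units higher from compound 1 to compound 2 (beyond the scatter) and cyano in place of hydrogen gave a number 0.30 log units lower from compound 1 to compound 3 (within the scatter) in the same read-out. Neither brings in a methyl or a ring nitrogen, so both guide only loosely. The entering ring holds a nitrogen, as the nitrile of compound 3 does, so compound 3 at 3.6 is the nearer guide. A modest fall is expected, with a number 0.50 log units lower from compound 1 to compound 4 (beyond the scatter) as the estimated step. For compound 4 the estimate is 3.4 with 2.9 to 3.9 as the expected range.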

Compound 4, distribution coefficient: 3.1
For compound 4 the middle estimate is 0.30 log units above the measured one, within the range that was stated.
By their numbers in this assay, from the lowest: compound 4; then compounds 3 and 1 (each within the scatter of the next); then compound 2.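

In this assay, 2-methylpyridin-3-yl in place of phenyl gives the first fall at this position that lies beyond the scatter, with a number 0.80 log units lower from compound 1 to compound 4 (beyond the scatter). The same ring also sits under both substituted phenyl rings, with a number 0.50 log units lower from compound 3 to compound 4 (beyond the scatter) and a number 1.30 log units lower from compound 2 to compound 4 (beyond the scatter), the last being a large step. This one position therefore spans a wider range than the first three compounds showed.

The entering ring brings a methyl and a ring nitrogen together, so telling their shares apart would take a pyridin-3-yl without the methyl or a 2-methylphenyl. Nothing measured here explains these steps.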